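A few compounds are considered here, and "the series" means these few. Any claim that something is new, unique, unknown or untested is made for them only; others in the source may bear on it.

Measured compounds in the series:
compound 1, `CC1=C(C(=O)C2CC2)C(c2ccco2)NC(=O)N1`: 1060 nM
compound 2, `CC1=C(C(=O)OCC2CCC2)C(c2ccco2)NC(=O)N1`: 561 nM

In an assay on membranes from HEK293 cells for displacement of a labelled ligand from adenosine receptor A2b (Homo sapiens), read by scintillation counting, with a stated time of 30 min (on this read-out higher numbers stand for weaker inhibition and lower numbers for stronger inhibition), compound 2 gives 561 nM and compound 1 gives 1060 nM. Among the measured compounds shown here, the two are not separated: the only measured step, a 1.9-fold lower number from compound 1 to compound 2 (0.28 log units; within the scatter), lies within the scatter, so compound 2 stands with compound 1 rather than apart from it.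

Compound 3, `CC1=C(C(=O)OCC2CCC2)C(c2ccsc2)NC(=O)N1`, keeps the carbonyl substituent of compound 2 and changes the group on the saturated ring carbon: thiophen-3-yl in place of furan-2-yl on a saturated ring carbon. For the measured compounds named here, no measured step bears on this change. Going by the values given here, the one step known, from compound 1 to compound 2, touches the cyclobutylmethoxy in place of cyclopropyl on the carbonyl carbon, a different place, and was itself within the scatter. Nothing in the measured pair speaks to swapping furan-2-yl for thiophen-3-yl, so the expectation for compound 3 rests on the default that a like-for-like five-membered ring exchange leaves the number where it is, with wide uncertainty.

Compound 3 is therefore expected to show no step beyond the scatter, a 1.1-fold higher number from compound 2 to compound 3 (0.03 log units; within the scatter), in this assay. The estimate for compound 3 is 600 nM, with a range from 200 nM to 2000 nM.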

Compound 3, inhibition constant: 1040 nM
Compound 3: middle estimate off by 1.7-fold (0.24 log units), on the low side; the measured number falls inside the stated range.
By their numbers in this assay, from the lowest: compounds 2, 3 and 1 (each within the scatter of the next).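

In this assay, among the compounds shown here, thiophen-3-yl in place of furan-2-yl on the saturated ring carbon gives a 1.9-fold higher number from compound 2 to compound 3 (0.27 log units; within the scatter), which is the first reading at this position, as the earlier step concerned only the group on the carbonyl carbon. The exchange does not separate the two compounds. In this pair, one five-membered aromatic ring with 1 hetero atom stands in place of another. The change alters both the hetero atom, sulfur for oxygen, and the point of attachment of the ring, so this single reading cannot assign any part of the small difference to either, and no supporting evidence bears on the result.

On these data alone, whether a group of another kind on this ring carbon, such as phenyl, cyclohexyl or an aminomethyl group, would produce a step beyond the scatter remains open, as do the matching isomers furan-3-yl and thiophen-2-yl, which would separate the hetero atom from the attachment point. Also open, as far as these compounds go, is whether thiophen-3-yl behaves the same way with cyclopropyl or a longer alkoxy chain on the carbonyl carbon.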